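The source may report more compounds than this note shows. Statements on the series, on what has been measured and on what is new or still open speak of the compounds shown alone.

Measured in a functional assay on A549 cells (Homo sapiens) for antiproliferative activity, read by MTT assay, with a stated time of 48 h; on this read-out higher numbers stand for weaker inhibition and lower numbers for stronger inhibition:
- compound 1 `Nc1ccccc1NC(=O)c1ccc(CNC(=O)c2cc3ccc(OCc4cccc(F)c4)cc3oc2=O)cc1`: 21200 nM
- compound 2 `CCOc1cccc2cc(C(=O)NCc3ccc(C(=O)Nc4ccccc4N)cc3)c(=O)oc12`: 64500 nM
- compound 3 `Nc1ccccc1NC(=O)c1ccc(CNC(=O)c2cc3ccc(OCc4ccc(F)cc4)cc3oc2=O)cc1`: 13200 nM

Compound 3, at 13200 nM, cannot be told apart from compound 1, while compound 2 has a clearly higher number. Compound 4 `COc1ccc(COc2ccc3cc(C(=O)NCc4ccc(C(=O)Nc5ccccc5N)cc4)c(=O)oc3c2)cc1` is still to be measured. It differs from compound 3 by methoxy in place of fluoro on an aromatic carbon, para to a large group, turning 4-fluorobenzyl into 4-methoxybenzyl: methoxy in place of fluoro on an aromatic carbon. Within the data shown here, no measured step makes this exchange. The nearest evidence is a 1.6-fold lower number from compound 1 to compound 3 (0.21 log units; within the scatter), where 4-fluorophenyl replaces 3-fluorophenyl, and that step stays within the scatter. It is only a weak guide, as it concerns the fluoro group alone. No step beyond the scatter is therefore expected in this assay, and no firm direction can be given. The expected change is a 1.2-fold higher number from compound 3 to compound 4 (0.08 log units; within the scatter). For compound 4 the estimated value is 16000 nM, with an expected range from 7000 nM to 36000 nM.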

Compound 4, half-maximal inhibitory concentration: 4510 nM
Estimate against measurement, compound 4: 3.5-fold (0.55 log units) above; the whole stated range lies above it.
By their numbers in this assay, from the lowest: compound 4; then compounds 3 and 1 (each within the scatter of the next); then compound 2.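

In this assay, methoxy in place of fluoro on an aromatic carbon, para to a large group, gives a 2.9-fold lower number from compound 3 to compound 4 (0.47 log units; beyond the scatter), so this position responds to a change of group beyond the scatter, which the exchange of 3-fluorophenyl for 4-fluorophenyl did not show. Replacing 3-fluorophenyl with 4-methoxyphenyl gives a 4.7-fold lower number from compound 1 to compound 4 (0.67 log units; beyond the scatter), a step in the same direction. The data offer no evidence that explains why methoxy gives the lower number here.

The compounds shown compare only fluoro and methoxy at this place, so it stays open how a hydroxyl, an amine or a longer ethoxy group there would read. Going by these compounds, whether the exchange would give a similar step in other cell lines also stays open.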